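Swapping the Aryl Ether Substituent in a Bicyclic Amine Series

The compounds below may be only part of what the source reports. "The series", "measured", "known", "first", "only" and "open" are said of these compounds alone.

Measured compounds:
Compound 1 `COc1ccccc1Oc1cncc(C2=CC3CNCC(C2)C3)c1`: 1 nM
Compound 2 `CN1CC2C=C(c3ccc(Cl)nc3)CC(C2)C1`: 22 nM

In an in vitro assay on SH-EP1 cells for displacement of a labelled ligand from Neuronal acetylcholine receptor; alpha4/beta2 (Homo sapiens) (a higher number here means a weaker inhibitor, a lower number a stronger inhibitor), compound 1 gives 1 nM, the lowest of the two numbers, while compound 2 gives 22 nM, a higher number that lies beyond the usual scatter. The two compounds differ in more than one place, so only their values can be set side by side.

Compound 3 `Clc1cccc(Oc2cncc(C3=CC4CNCC(C3)C4)c2)c1` has not yet been measured. It differs from compound 1 by 3-chlorophenyl in place of 2-methoxyphenyl on an oxygen on an aromatic ring. Going by the values given here, no step between measured compounds probes a change of this kind, so its size can only be guessed. Because compound 1 already stands at 1 nM in this assay, the expectation for compound 3 is a small weakening or none beyond the scatter. The estimate for compound 3 in this assay is 2 nM, with a range from 0.5 nM to 8 nM. The expected step of a 2.0-fold higher number from compound 1 to compound 3 (0.30 log units; within the scatter) is modest.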

Compound 3, inhibition constant: 1 nM
For compound 3 the middle estimate is 2.0-fold (0.30 log units) above the measured one, and the stated range covers the measured number.
By their numbers in this assay, from the lowest: compounds 1 and 3 (each within the scatter of the next); then compound 2.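

In this assay, replacing 2-methoxyphenyl with 3-chlorophenyl on the ether oxygen gives no change at the digits printed from compound 1 to compound 3 (within the scatter) and leaves the value where it was. Going by these compounds alone, this is the first direct test of this position, and it shows that the position accepts a different aryl group, even though the incoming group has a chlorine in place of the methoxy oxygen and one hydrogen-bond acceptor fewer. Nothing available explains why the two groups give the same reading.

Going by these compounds, both groups are substituted phenyl rings, so it remains open whether the value would hold with a carboxylic acid or an amine on the ring, or with a longer chain in place of the ring. Compound 2 has no such ether and differs in more than one place, so it cannot show whether the same swap would behave alike on another core.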